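The compounds below may be only part of what the source reports. "The series", "measured", "known", "first", "only" and "open" are said of these compounds alone.

Compound 1, `Cc1ccc(C(=O)Oc2ccc(Cl)cc2C(=O)Nc2ccc(Cl)c(Cl)c2)cc1`, in an ADME assay on HepG2 cells (Homo sapiens) for cytotoxicity, read by MTT assay, with a stated time of 72 h (a higher number here means a weaker inhibitor, a lower number a stronger inhibitor), gives > 50000 nM, which is a limit of the assay.
Compound 2, `Cc1ccc(C(=O)Oc2ccc(Cl)cc2C(=O)Nc2ccc(C(F)(F)F)cc2)cc1`, in this assay gives > 50000 nM, again a limit.
Compound 3, `Cc1ccc(C(=O)Oc2ccc(Br)cc2C(=O)Nc2ccc(C(F)(F)F)cc2)cc1`, in this assay gives > 50000 nM, also a limit.

Among the compounds with values here, compound 2 therefore stands where every value so far stands: at the limit, with the limit of > 50000 nM in this assay, at which 3 of the 3 values shown sit. The change studied here is nitro in place of methyl on an aromatic carbon, on the ester-side ring, and it gives compound 4, `O=C(Oc1ccc(Cl)cc1C(=O)Nc1ccc(C(F)(F)F)cc1)c1ccc([N+](=O)[O-])cc1`. Two measured steps exist, a step that the two limits leave unreadable from compound 1 to compound 2 and a step that the two limits leave unreadable from compound 2 to compound 3, and neither is readable; neither touches the ester-side ring. Within the data shown here, no step is therefore expected for compound 4 beyond the scatter, so its estimated value in this assay is 60000 nM, between 20000 nM and 200000 nM. The expected step is a step that the limit leaves unreadable from compound 2 to compound 4.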

Compound 4, half-maximal inhibitory concentration: > 50000 nM
Compound 4: a limit, no number (the forecaster's own chance of this, stated with the estimate: 80%); the middle value does not contradict the limit.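

Compound 2 and compound 4 both sit at a limit, so no step can be read between them: the limit of > 50000 nM in this assay, at which 4 of the 4 values shown sit.

The compounds shown leave open whether any of these changes moves the value in this assay at all.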